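Piperidin-1-yl for anilino on the shared core

The source may report more compounds than this note shows. Statements on the series, on what has been measured and on what is new or still open speak of the compounds shown alone.

Compound 1 `O=C1C(Nc2ccccc2)=CC(=O)c2c1nc1n2[C@H]2OC[C@@H](O)[C@H]2OC1` gives > 4000 nM (a limit)
Compound 2 `CCc1ccc(NC2=CC(=O)c3nc4n(c3C2=O)[C@H]2OC[C@@H](O)[C@H]2OC4)cc1` gives 960 nM (a number)

In a functional assay on MCF7 cells (Homo sapiens) for inhibition, read by sulforhodamine B assay (a higher number here means a weaker inhibitor, a lower number a stronger inhibitor), compound 1 stands at > 4000 nM as a limit of the assay, not a number. Compound 3 `O=C1C(N2CCCCC2)=CC(=O)c2c1nc1n2[C@H]2OC[C@@H](O)[C@H]2OC1` carries the change piperidin-1-yl in place of anilino on a double-bonded ring carbon with piperidin-1-yl in place of anilino on a double-bonded ring carbon. Among the measured compounds shown here, no measured step speaks to this change. The expected step of a number no higher from compound 1 to compound 3 (the limit leaves the size open) is therefore none beyond the scatter, in either direction. In this assay the expected value for compound 3 is 4000 nM (estimated range 1200 nM to 12000 nM).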

Compound 3, half-maximal inhibitory concentration: > 8000 nM
Compound 3 ended at the assay's limit; the forecaster's own chance of this, stated with the estimate: 50%; middle value at least 2.0-fold (0.30 log units) from the limit.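

Among the compounds shown here, compound 1 and compound 3 both stand at limits in this assay, so no step between them can be read. The compounds shown leave open what size of change, and in which direction, piperidin-1-yl in place of anilino brings.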